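This account rests on a few compounds, and the source may have more. Where it says the series, first, only, none or still open, it means among the compounds named here.

Compound 1 `CCN(Cc1cc[nH]n1)C(=O)COc1ccc(C)cc1` carries an ethyl group and a pyrazolylmethyl group on its amide-type nitrogen; in an assay on HEK293 cells for agonist activity at transient receptor potential cation channel subfamily M member 8 (Homo sapiens), read by fluorescence and calcium flux, with a stated time of 15 min (on this read-out higher numbers stand for an effect only at larger amounts of compound and lower numbers for an effect already at smaller amounts), compound 1 is reported as "not active" (no number reported). Among the measured compounds shown here, compound 2 `Cc1ccc(OCC(=O)N(Cc2cccs2)c2nccs2)cc1` gives the only number in this assay, namely 2240 nM, so it stands alone as the sole reference point. Compound 3 `Cc1ccc(OCC(=O)N(Cc2cccs2)c2c[nH]nc2C)cc1` differs from compound 2 in one place: 3-methyl-1H-pyrazol-4-yl in place of 1,3-thiazol-2-yl on an amide-type nitrogen. For the measured compounds named here, no measured pair shows such a change, so the step from compound 2 to compound 3 is expected to be a modest weakening, a 2.0-fold higher number from compound 2 to compound 3 (0.30 log units; within the scatter), with wide uncertainty. Compound 3 is therefore estimated at 4500 nM, within a range from 1500 nM to 15000 nM.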

Compound 3, half-maximal effective concentration: 0.4 nM
For compound 3 the middle estimate is 11000-fold (4.05 log units) above the measured one; the whole stated range lies above it.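

In this assay, the group on the amide-type nitrogen proves to be a highly sensitive place: 3-methyl-1H-pyrazol-4-yl in place of 1,3-thiazol-2-yl gives a 5600-fold lower number from compound 2 to compound 3 (3.75 log units; beyond the scatter). Both groups are five-membered aromatic rings with two hetero atoms, so a swap that keeps this ring size can still move the number enormously. Nothing measured here explains a step of this size. On these data alone, the methyl group, the ring's hydrogen-bond donor and the ring atoms all change together, so their separate shares remain open. A 1H-pyrazol-4-yl group without the methyl, or a phenyl group on the same nitrogen, would help tell them apart.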